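Three bis-amides inactive; a small polar amide replaces the cyclopropyl

This account rests on a few compounds, and the source may have more. Where it says the series, first, only, none or still open, it means among the compounds named here.

Compound 1 `O=C(Nc1cccc(NC(=O)c2cccc(Cl)c2)c1)c1cccc(F)c1`: in an in vitro functional assay on HEK293-A cells for antagonist activity at metabotropic glutamate receptor 5 (Rattus norvegicus), read by calcium flux (a higher number here means a weaker inhibitor, a lower number a stronger inhibitor), compound 1 gives > 30000 nM, which is a limit of the assay.
Compound 2 `O=C(Nc1cccc(NC(=O)c2cccc(Cl)c2)c1)c1ccc(F)cc1`: in this assay compound 2 gives > 30000 nM, again a limit of the assay.
Compound 3 `O=C(Nc1cccc(NC(=O)C2CC2c2ccccc2)c1)c1cccc(Cl)c1`: in this assay compound 3 gives > 30000 nM, also a limit of the assay.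

Compound 3 therefore stands at the common limit, (the limit of > 30000 nM in this assay, at which 3 of the 3 values shown sit). The steps among the measured compounds are all unreadable: a step that the two limits leave unreadable from compound 1 to compound 2, a step that the two limits leave unreadable from compound 1 to compound 3 and a step that the two limits leave unreadable from compound 2 to compound 3. None of them gives a size or a direction, so the series offers no measured guide to how the amide substituent on this carbonyl carbon moves the read-out.

Compound 4 `COCC(=O)Nc1cccc(NC(=O)c2cccc(Cl)c2)c1` is the next member. The change from compound 3 is methoxymethyl in place of 2-phenylcyclopropyl on a carbonyl carbon. Within the data shown here, the only evidence bearing on it is the limit at which compound 3 sits, so the expected step that the limit leaves unreadable from compound 3 to compound 4 is most likely no readable change at all. Compound 4 is expected to give roughly 40000 nM in this assay, with a range of 10000 nM to 150000 nM, and most probably only a limit rather than a number.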

Compound 4, half-maximal inhibitory concentration: > 30000 nM
Compound 4 ended at the assay's limit; the forecaster's own chance of this, stated with the estimate: 85%; the middle value does not contradict the limit.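

No step to compound 4 from compound 1, compound 2 or compound 3 can be read, since all four compounds sit at the same assay limit: the limit of > 30000 nM in this assay, at which 4 of the 4 values shown sit.

The compounds shown leave open whether any substituent on this carbonyl carbon gives a readable inhibitory concentration.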